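Replacing 3-methylphenyl with 3,4-difluorophenyl: compound 4

The source may hold more compounds than are shown below. What is called first, only, known or untested is meant among the compounds shown, and "the series" means these compounds.

Working notes on the series. In an assay on isolated protein for inhibition of protein deacetylase HDAC6 (Homo sapiens), read by fluorescence, with a stated time of 1 h, tested at 100 nM (a higher number here means more inhibition at the concentration tested (going by the name of the read-out), a lower number less inhibition), compound 1 `O=C(/C=C/c1ccc(OCc2nc(C3CCN(Cc4ccccc4)CC3)no2)cc1)NO` gives 71%, compound 2 `Cc1cccc(CN2CCC(c3noc(COc4ccc(/C=C/C(=O)NO)cc4)n3)CC2)c1` gives 73%, and compound 3 `O=C(/C=C/c1ccc(OCc2nc(C3CCN(Cc4ccccc4F)CC3)no2)cc1)NO` gives 68%. Compound 2 carries the top number of the three, but its gaps to the others stay inside the scatter: a number 2 percentage points higher from compound 1 to compound 2 (within the scatter) and a number 5 percentage points lower from compound 2 to compound 3 (within the scatter). Compound 4 `O=C(/C=C/c1ccc(OCc2nc(C3CCN(Cc4ccc(F)c(F)c4)CC3)no2)cc1)NO` differs from compound 2 by 3,4-difluorophenyl in place of 3-methylphenyl on a saturated chain carbon bound to an amine nitrogen in a ring. Among the compounds with values here, two measured steps bear on this change, a number 5 percentage points lower from compound 2 to compound 3 (within the scatter) and a number 3 percentage points lower from compound 1 to compound 3 (within the scatter), and neither reaches beyond the scatter. No step beyond the scatter is therefore expected here. Compound 4 is expected to give 69%, with a range from 58% to 80%. The expected step is a number 4 percentage points lower from compound 2 to compound 4 (within the scatter).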

Compound 4, a percentage reported as inhibition, at one concentration (the size of the read-out at that concentration, not a potency): 60%
For compound 4 the middle estimate is 9 percentage points above the measured one; the measured number falls inside the stated range.
By their numbers in this assay, from the lowest: compounds 4, 3, 1 and 2 (each within the scatter of the next, the first and the last beyond it).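

In this assay, the position on a saturated chain carbon bound to an amine nitrogen in a ring now gives steps beyond the scatter, with a number 13 percentage points lower from compound 2 to compound 4 (beyond the scatter) and a number 11 percentage points lower from compound 1 to compound 4 (beyond the scatter) both modest. The change from 2-fluorophenyl does not separate the pair, with a number 8 percentage points lower from compound 3 to compound 4 (within the scatter) as its step. The group at this position therefore matters to a modest degree, but only against phenyl and 3-methylphenyl.

From the compounds shown here alone, whether a methoxy group or a nitrile on the phenyl ring would give a similar step remains open. Nothing on hand accounts for the steps seen with 3,4-difluorophenyl.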